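The compounds below may be only part of what the source reports. "The series", "measured", "known", "first", "only" and "open" are said of these compounds alone.

Going by the values given here, compound 1 `Cc1ccc(NC2=CC(=O)c3nc4n(c3C2=O)[C@H]2OC[C@@H](O)[C@H]2OC4)cc1C` gives 2080 nM in a functional assay on MCF7 cells (Homo sapiens) for inhibition, read by sulforhodamine B assay (on this read-out lower numbers stand for stronger inhibition and higher numbers for weaker inhibition), and stands at the lowest of the two numbers known in this study. Compound 2 `Cc1ccc(NC2=CC(=O)c3c(nc4n3[C@H]3OC[C@@H](O)[C@H]3OC4)C2=O)cc1C` gives 4950 nM in this assay, a gap to compound 1 that lies beyond the usual scatter. Compound 3 `CCOc1ccc(NC2=CC(=O)c3c(nc4n3[C@H]3OC[C@@H](O)[C@H]3OC4)C2=O)cc1` gives only a limit of the assay, > 4000 nM. Among the compounds with values here, because compound 3 sits at the limit of > 4000 nM in this assay, at which 1 of the 3 values shown sits, the single measured step, a step that the limit leaves unreadable from compound 2 to compound 3, cannot be given a size, and it changes one aryl group for another rather than leaving the aromatic ring altogether.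

Compound 4 `O=C1C=C(NC2CCCCC2)C(=O)c2c1nc1n2[C@H]2OC[C@@H](O)[C@H]2OC1` differs from compound 1 by cyclohexyl in place of 3,4-dimethylphenyl on an amine nitrogen. Within the data shown here, no measured step in this set bears on a change of this kind, since the only step recorded is unreadable and of a different nature, so the direction and size of the change rest on the structural difference alone. Compound 4 is expected to give 4000 nM in this assay, with a range from 1500 nM to 12000 nM. The expected step is a 1.9-fold higher number from compound 1 to compound 4 (0.28 log units; within the scatter).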

Compound 4, half-maximal inhibitory concentration: > 8000 nM
Compound 4 was reported as a limit (the forecaster's own chance of this, stated with the estimate: 40%); middle value at least 2.0-fold (0.30 log units) from the limit.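

On the amine nitrogen, replacing 3,4-dimethylphenyl with cyclohexyl in this assay gives an at least 3.8-fold higher number from compound 1 to compound 4 (0.58 log units; beyond the scatter). The earlier compounds shown here only exchanged one aryl group for another, in a step that cannot be read, whereas this pair gives a readable minimum for leaving the aromatic ring for a non-aromatic ring of carbon, with the lower number on the aromatic side. The full size of the step cannot be given, because compound 4 is reported only as a limit: the limit of > 8000 nM in this assay, at which 1 of the 4 values shown sits.

From the compounds shown here alone, it remains open whether a plain phenyl, a benzyl group or an open-chain hexyl group on this nitrogen would stay close to compound 1. Going by these compounds, it is also open whether cyclohexyl in place of 3,4-dimethylphenyl on the core of compound 2 would give a similar step.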